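The compounds below may be only part of what the source reports. "The series", "measured", "known", "first", "only" and "open" are said of these compounds alone.

Measured in a functional assay on cells (leukaemia cell line, Homo sapiens) for inhibition, read by sulforhodamine B assay, with a stated time of 48 h; on this read-out higher numbers stand for lower toxicity in this test and lower numbers for higher toxicity in this test:
- compound 1 `O=S(=O)(Nc1ccc(Cl)c(F)c1)c1ccc(-c2cnc(C3CC3)o2)cc1`: > 100000 nM, a limit
- compound 2 `Cc1cc(NS(=O)(=O)c2ccc(-c3cnc(C4CC4)o3)cc2)ccc1Cl`: > 100000 nM, a limit
- compound 3 `O=S(=O)(Nc1cc(Cl)ccc1Cl)c1ccc(-c2cnc(C3CC3)o2)cc1`: > 100000 nM, a limit

Compound 3 has no number, only the limit > 100000 nM. The whole series sits at the limit of > 100000 nM in this assay, at which 3 of the 3 values shown sit.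

The next compound is compound 4 `O=S(=O)(Nc1cc(F)cc(F)c1)c1ccc(-c2cnc(C3CC3)o2)cc1`, which has 3,5-difluorophenyl in place of 2,5-dichlorophenyl on a sulfonamide nitrogen.

The closest precedents are the other exchanges of the group on that nitrogen, a step that the two limits leave unreadable from compound 1 to compound 3 and a step that the two limits leave unreadable from compound 2 to compound 3. The remaining measured change, methyl in place of fluoro, is a step that the two limits leave unreadable from compound 1 to compound 2. None of these gives a size or a direction, so no step beyond the scatter is expected in this assay.

With all three measured compounds at the same limit, another limit is the likeliest report. The expected outcome is a number no higher from compound 3 to compound 4 (the limit leaves the size open). For compound 4 the estimated value is 100000 nM, with an expected range from 40000 nM to 150000 nM.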

Compound 4, concentration lethal to 50% of the cells: > 100000 nM
Compound 4 ended at the assay's limit (the forecaster's own chance of this, stated with the estimate: 85%); the middle value lies on the limit itself.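

In this assay compound 4 gives > 100000 nM, a limit, so no step from compound 1, compound 2 or compound 3 to compound 4 can be read: the limit of > 100000 nM in this assay, at which 4 of the 4 values shown sit.

The compounds shown leave open which group on the sulfonamide nitrogen, if any, would give a readable number in this test.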